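What Trading Fluoro for Hydrogen May Do

A few compounds are considered here, and "the series" means these few. Any claim that something is new, unique, unknown or untested is made for them only; others in the source may bear on it.

Compound 1 `O=C(N/N=C/c1cccc(Br)c1)Nc1ccc(Oc2ccnc3[nH]ccc23)c(F)c1`: 660 nM
Compound 2 `O=C(N/N=C/c1ccc(O)cc1)Nc1ccc(Oc2ccnc3[nH]ccc23)c(F)c1`: 1950 nM
Compound 3 `COc1ccc(/C=N/NC(=O)Nc2ccc(Oc3ccnc4[nH]ccc34)c(F)c2)cc1`: 1770 nM

All three were tested in a functional assay on HepG2 cells (Homo sapiens) for antiproliferative activity, read by MTT assay, with a stated time of 72 h; a higher number here means a weaker inhibitor, a lower number a stronger inhibitor. Compound 2 stands at the high end of this set: the gap to its closest value is a 1.1-fold lower number from compound 2 to compound 3 (0.04 log units; within the scatter), and the widest gap is a 3.0-fold higher number from compound 1 to compound 2 (0.47 log units; beyond the scatter). Compound 4 `O=C(N/N=C/c1ccc(O)cc1)Nc1ccc(Oc2ccnc3[nH]ccc23)cc1` carries one change from compound 2: hydrogen in place of fluoro on an aromatic carbon. Going by the values given here, no measured step touches that place, since all three change a different part of the molecule, and the largest of them is only modest. No shift beyond the scatter is therefore expected, in either direction. The estimated step is a 1.1-fold higher number from compound 2 to compound 4 (0.05 log units; within the scatter). In this assay, compound 4 is expected at 2200 nM, with an estimated range of 900 nM to 5000 nM.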

Compound 4, half-maximal inhibitory concentration: 32200 nM
For compound 4 the middle estimate is 15-fold (1.17 log units) below the measured one; measured number above the stated range.
By their numbers in this assay, from the lowest: compound 1; then compounds 3 and 2 (each within the scatter of the next); then compound 4.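

With hydrogen in place of fluoro on this aromatic carbon, ortho to a large group, this assay shows a 17-fold higher number from compound 2 to compound 4 (1.22 log units; beyond the scatter). This single-atom change outweighs every step among compound 1, compound 2 and compound 3, so this position matters far more than those earlier steps could suggest. Nothing measured here bears on why the step is so large. Going by these compounds alone, the change is seen only with the 4-hydroxyphenyl group, so whether it carries over to compound 1 or compound 3 stays open. Going by these compounds, how chloro or methyl would compare with fluoro on this carbon also remains unknown.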